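This account rests on a few compounds, and the source may have more. Where it says the series, first, only, none or still open, it means among the compounds named here.

Compound 1 `COc1ccc(-c2c(Nc3cc(OC)c(OC)c(OC)c3)c3ccccc3oc2=O)cc1` gives 77300 nM
Compound 2 `COc1ccc(-c2c(Nc3ccc(F)cc3)c3ccccc3oc2=O)cc1` gives 35500 nM
Compound 3 `COc1ccc(-c2c(Nc3ccc(C)c(O)c3)c3ccccc3oc2=O)cc1` gives 10200 nM

All three values come from a functional assay on HepG2 cells (Homo sapiens) for antiproliferative activity, read by MTT assay, with a stated time of 48 h (on this read-out lower numbers stand for stronger inhibition and higher numbers for weaker inhibition), and compound 1 has the highest number of the three, which makes it the weakest of this small set. Compound 2 and compound 3 both give lower numbers.

Compound 4 `COc1ccc(-c2c(Nc3cc(OC)c(OC)c(OC)c3)c3ccc(OC)cc3oc2=O)cc1` keeps all of compound 1 except for one place on the shared core. The change is methoxy in place of hydrogen on an aromatic carbon and in short it is methoxy in place of hydrogen on an aromatic carbon, on the carbon-only ring of the fused system.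

Among the measured compounds shown here, the one measured step of a 3.5-fold lower number from compound 2 to compound 3 (0.54 log units; beyond the scatter) is a change to the group on the nitrogen and leaves the core untouched. It shows that the numbers can move with a change elsewhere in the molecule, but it does not test this one. For the measured compounds named here, no measured compound carries any group at the new place, so the data point in neither direction. On these data alone, no step beyond the scatter is therefore expected, and the estimated move is a 1.1-fold lower number from compound 1 to compound 4 (0.04 log units; within the scatter) with either direction still open. In this assay compound 4 is estimated at 70000 nM with an expected range from 28000 nM up to 150000 nM as its upper end.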

Compound 4, half-maximal inhibitory concentration: 84300 nM
For compound 4 the middle estimate is 1.2-fold (0.08 log units) below the measured one; the measured number falls inside the stated range.
By their numbers in this assay, from the lowest: compound 3; then compound 2; then compounds 1 and 4 (each within the scatter of the next).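

In this assay, methoxy in place of hydrogen on an aromatic carbon of the shared core gives a 1.1-fold higher number from compound 1 to compound 4 (0.04 log units; within the scatter), a step that stays within the usual scatter of repeated measurements. Among the compounds shown here, the earlier compounds differ only in the group on the nitrogen, whereas this pair gives the first reading at this place, which is meta to one fused ring and para to another: with the group on the nitrogen of compound 1 kept, this added methoxy leaves no difference that can be told apart from the scatter. Nothing available here explains the result.

This single pair does not show whether a larger or different group at the same place, such as an amine, a carboxylic acid or a longer chain, would also leave the number within the scatter. It also leaves open whether methoxy at this place would have as little effect when compound 2 or compound 3 supplies the group on the nitrogen, since compound 3 gives the lowest number of the set at 10200 nM.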